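Extending the Sulfonamide Nitrogen of Compound 2

This account rests on a few compounds, and the source may have more. Where it says the series, first, only, none or still open, it means among the compounds named here.

Compound 1: `CC#C[C@H]1CN(S(=O)(=O)c2ccc(N)nc2)CCN1c1ncc(C(C)(O)C(F)(F)F)s1` — > 12500 nM
Compound 2: `CC#C[C@H]1CN(S(=O)(=O)c2ccc(N)nc2)CCN1c1ccc(S(N)(=O)=O)cc1` — 37 nM
Compound 3: `CC#C[C@H]1CN(S(=O)(=O)c2ccc(N)nc2)CCN1c1ccc(C(C)(O)C(F)(F)F)nc1` — 1450 nM

In an assay on cells (Hepatocyte) for inhibition of glucokinase regulatory protein (Mus musculus), with stated times of 20 min and 40 min (on this read-out lower numbers stand for an effect already at smaller amounts and higher numbers for an effect only at larger amounts of compound), compound 1 gives only a limit, > 12500 nM, which is the limit (the limit of > 12500 nM in this assay, at which 1 of the 3 values shown sits). Compound 2 gives 37 nM in this assay, and compound 3 gives 1450 nM. Among the two numbers actually measured, compound 2 stands lowest, and its distance from compound 3 lies beyond the scatter of repeated measurements. Within the data shown here, no pair of these three compounds differs in only one place, so no single step between measured compounds can be read from them; they simply show how the three shared-core compounds compare.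

Compound 4, `CC#C[C@H]1CN(S(=O)(=O)c2ccc(N)nc2)CCN1c1ccc(S(=O)(=O)NCC2CC2)cc1`, is built from compound 2 by one change: cyclopropylmethyl in place of hydrogen on a sulfonamide nitrogen. Among the measured compounds shown here, no measured step of this kind is available here, so the expectation rests on compound 2 alone. A modest step toward higher numbers is expected, a 3.2-fold higher number from compound 2 to compound 4 (0.51 log units; beyond the scatter), though it may well stay within the scatter. Compound 4 is therefore estimated at 120 nM in this assay, with a range from 30 nM to 600 nM.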

Compound 4, half-maximal effective concentration: 271 nM
Compound 4: the middle estimate sits 2.3-fold (0.35 log units) below what was measured, within the range that was stated.
By their numbers in this assay, from the lowest: compound 2; then compound 4; then compound 3. At a limit, above all of these: compound 1.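

Among these compounds, this is the first step that can be read at a single place: in this assay, cyclopropylmethyl in place of hydrogen on a sulfonamide nitrogen gives a 7.3-fold higher number from compound 2 to compound 4 (0.86 log units; beyond the scatter). The read-out therefore responds to substitution at this nitrogen, and the number moves upward, yet compound 4 still gives a measured value of 271 nM, so this substituent is accommodated at a modest cost. Nothing measured here bears on why the step goes this way.

With a single step at this place, the compounds shown cannot separate the contribution of the three-membered ring from that of the added carbon chain, a question that a plain n-butyl group on the same nitrogen would address. They also leave open how far the number depends on the size and kind of substituent here, from a single methyl group to a longer chain ending in an amine or a carboxylic acid, and whether any group on this nitrogen would leave the number where the free sulfonamide of compound 2 has it.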